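Fluorine Removal on a Nitro-Sulfone Piperidine Amide Series

A few compounds are considered here, and "the series" means these few. Any claim that something is new, unique, unknown or untested is made for them only; others in the source may bear on it.

Compound 1 `CS(=O)(=O)c1ccc(C(=O)N2CCC(C(=O)N(Cc3ccccc3)Cc3ccccc3)CC2)cc1[N+](=O)[O-]` gives > 60000 nM in an assay on isolated protein for inhibition of thyroid hormone receptor alpha (Homo sapiens), read by fluorescence polarization; on this read-out higher numbers stand for weaker inhibition and lower numbers for stronger inhibition; this value is a limit of the assay.
Compound 2 `CS(=O)(=O)c1ccc(C(=O)N2CCC(C(=O)N3CCc4ccccc4C3)CC2)cc1[N+](=O)[O-]` gives > 60000 nM in this assay; this value is a limit.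
Compound 3 `CN(Cc1ccccc1F)C(=O)C1CCN(C(=O)c2ccc(S(C)(=O)=O)c([N+](=O)[O-])c2)CC1` gives > 60000 nM in this assay; this value is a limit.

Compound 3 therefore stands only at a limit, as every value in this set does (the limit of > 60000 nM in this assay, at which 3 of the 3 values shown sit). Going by the values given here, the single measured step, a step that the two limits leave unreadable from compound 2 to compound 3, is unreadable for the same reason, so no measured step gives a size to build on. The unmeasured compound 4 `CN(Cc1ccccc1)C(=O)C1CCN(C(=O)c2ccc(S(C)(=O)=O)c([N+](=O)[O-])c2)CC1` differs from compound 3 by hydrogen in place of fluoro on an aromatic carbon. With all three values at the limit, compound 4 is expected to stay at that limit, a step that the limit leaves unreadable from compound 3 to compound 4 or none readable. The estimate for compound 4 is 90000 nM, within 30000 nM to 300000 nM.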

Compound 4, half-maximal inhibitory concentration: > 60000 nM
Compound 4: no number, only a limit; the forecaster's own chance of this, stated with the estimate: 85%; the middle value does not contradict the limit.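

Compound 4 sits at a limit, as compounds 1, 2 and 3 do, so no step among these compounds can be read in this assay: the limit of > 60000 nM in this assay, at which 4 of the 4 values shown sit.

The compounds shown leave open whether any change to the shared core gives a measurable value.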